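Moving the methoxy group: compound 1 to compound 4

The source may report more compounds than this note shows. Statements on the series, on what has been measured and on what is new or still open speak of the compounds shown alone.

Compound 1 `Cc1ccc(-c2c(C)nn(-c3nc(-c4ccc(Cl)c(Cl)c4)c(SC(C)C)s3)c2C(=O)O)cc1` is tested in a functional assay on BJAB cells (Homo sapiens) for antiproliferative activity, with a stated time of 4 days (a higher number here means that more compound is needed for the effect, a lower number that less compound is needed), where compound 1 gives 3800 nM, the lowest of the three numbers shown. Compound 2 `COc1ccccc1-c1c(C)nn(-c2nc(-c3ccc(Cl)c(Cl)c3)c(SC(C)C)s2)c1C(=O)O` gives 14700 nM and compound 3 `Cc1nn(-c2nc(-c3ccc(Cl)c(Cl)c3)c(SC(C)C)s2)c(C(=O)O)c1-c1ccccc1[N+](=O)[O-]` gives 4700 nM; the related step of a 3.9-fold higher number from compound 1 to compound 2 (0.59 log units; beyond the scatter) is modest, while a 1.2-fold higher number from compound 1 to compound 3 (0.09 log units; within the scatter) stays within the scatter, and a 3.1-fold lower number from compound 2 to compound 3 (0.50 log units; beyond the scatter) is modest. Compound 4 `COc1cccc(-c2c(C)nn(-c3nc(-c4ccc(Cl)c(Cl)c4)c(SC(C)C)s3)c2C(=O)O)c1` differs from compound 1 as follows: 3-methoxyphenyl in place of 4-methylphenyl on an aromatic carbon. The nearest measured guide is the methoxy-bearing compound 2, whose step a 3.9-fold higher number from compound 1 to compound 2 (0.59 log units; beyond the scatter) suggests that a methoxyphenyl ring in this position can raise the number. Compound 4 is therefore expected to show a modest rise, a 2.0-fold higher number from compound 1 to compound 4 (0.30 log units; within the scatter), with an estimated value of 7500 nM in this assay, likely between 3000 nM and 19000 nM.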

Compound 4, half-maximal effective concentration: 14000 nM
Compound 4: middle estimate off by 1.9-fold (0.27 log units), on the low side; low and high end bracket the measured number.
By their numbers in this assay, from the lowest: compounds 1 and 3 (each within the scatter of the next); then compounds 4 and 2 (each within the scatter of the next).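

Shifting the methoxy group makes no clear difference (a 1.1-fold lower number from compound 2 to compound 4 (0.02 log units; within the scatter)), so 3-methoxyphenyl and 2-methoxyphenyl cannot be told apart at this position. The rise seen with compound 2 is therefore not confined to one methoxy placement: 3-methoxyphenyl also raises the number relative to 4-methylphenyl (a 3.7-fold higher number from compound 1 to compound 4 (0.57 log units; beyond the scatter)), and the number also lies above that of the 2-nitrophenyl compound (a 3.0-fold higher number from compound 3 to compound 4 (0.47 log units; beyond the scatter)). Nothing available explains these steps.

Going by these compounds, it remains open how a phenyl ring bearing an amine or a longer chain would behave here. On these data alone, it is also open whether any group at this position could bring the number below that of compound 1.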